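This account rests on a few compounds, and the source may have more. Where it says the series, first, only, none or still open, it means among the compounds named here.

Measured compounds and their results:

- compound 1, `O=c1cc(/C=N\c2ccccc2O)c2ccc(OCc3ccccc3)cc2o1`: 1290 nM
- compound 2, `O=c1cc(/C=N\O)c2c(OCc3ccccc3)cc(OCc3ccccc3)cc2o1`: 38700 nM

Compound 1 is the stronger of the two measured inhibitors in a functional assay, read by spectrophotometry, with a stated time of 3 min; on this read-out higher numbers stand for weaker inhibition and lower numbers for stronger inhibition. Compound 2 gives a number in this assay that lies far above that of compound 1, a gap that is well beyond the usual scatter, but the two differ in more than one place, so the comparison says only what the two values show.

Compound 3, `O=c1cc(/C=N\Nc2ccccc2)c2ccc(OCc3ccccc3)cc2o1`, has not yet been measured. It keeps the core of compound 1 and differs from it in a single way: anilino in place of 2-hydroxyphenyl on a double-bonded nitrogen. Going by the values given here, no measured pair in this set isolates such a change, so there is no directly comparable step to lean on.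

In the absence of such a precedent, the step from compound 1 to compound 3 is expected to be modest, with the number for compound 3 estimated to come out somewhat higher, at about a 1.9-fold higher number from compound 1 to compound 3 (0.29 log units; within the scatter). Compound 3 is therefore expected to give roughly 2500 nM in this assay, within a range from 600 nM to 10000 nM.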

Compound 3, half-maximal inhibitory concentration: 13200 nM
The estimate for compound 3 lay 5.3-fold (0.72 log units) below the measured number; the measured number lies above the stated range.
By their numbers in this assay, from the lowest: compound 1; then compound 3; then compound 2.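

Going by these compounds alone, the step from 2-hydroxyphenyl to anilino is the first change in this set that can be read at a single place, on a double-bonded nitrogen whose other neighbour is the carbon with a double bond to nitrogen, and in this assay it gives a 10-fold higher number from compound 1 to compound 3 (1.01 log units; beyond the scatter) on the shared core. The earlier pair could not show this, as compound 1 and compound 2 differ in more than one place, whereas here a large weakening of inhibition follows a swap between two groups with the same count of heavy atoms, the same six-membered aromatic ring of carbon only, the same counts of hydrogen-bond donors and acceptors, and no net charge, so these counts do not separate the two groups, while the numbers do. Nothing measured here accounts for the size of this step.

The compounds shown leave open whether the step goes with the loss of the oxygen or with the entry of the nitrogen, as the two changes come together in this single swap. They also leave open how an amine or a carboxylic acid on the phenyl ring of compound 1 would read in this assay.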